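This account rests on a few compounds, and the source may have more. Where it says the series, first, only, none or still open, it means among the compounds named here.

Three measured compounds of the series share a chloroacetyl amide unit and differ in what is attached to it. Compound 1 `CC(C)(C)c1ccc(CNC(=O)NC(=O)CCl)cc1` carries a benzylurea; in a functional assay on M21 cells (Homo sapiens) for antiproliferative activity, with a stated time of 48 h (on this read-out higher numbers stand for weaker inhibition and lower numbers for stronger inhibition), compound 1 gives 2400 nM. Compound 2 `CCCCC(OC)c1cccc(NC(=O)NC(=O)CCl)c1` carries an arylurea, and in this assay compound 2 gives 4200 nM, a number that sits within the scatter of that of compound 1. Compound 3 `O=C(CCl)Nc1ccc(I)cc1` is the plain anilide, and in this assay compound 3 gives 5100 nM, a number beyond the scatter above that of compound 1. Compound 1 thus has the lowest number of the three, though it is not separated from compound 2.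

Compound 4 `CC(C)(C)c1ccc(CNC(=O)CCCl)cc1` has not been measured. It differs from compound 1 in one place: 2-chloroethyl in place of ((chloromethyl)carbonyl)amino on a carbonyl carbon. The urea link and the chloroacetyl unit that all three measured compounds hold are thereby gone, and the chlorine now sits at the end of a three-carbon chain on the amide. For the measured compounds named here, no measured pair covers this change, so nothing fixes its size. Given that every measured compound keeps the chloroacetyl amide, the expectation for compound 4 is a step of a 5.0-fold higher number from compound 1 to compound 4 (0.70 log units; beyond the scatter) towards weaker inhibition, beyond the scatter. The estimate for compound 4 in this assay is 12000 nM, with a range from 3500 nM to 40000 nM.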

Compound 4, half-maximal inhibitory concentration: > 100000 nM
Compound 4 ended at the assay's limit (the forecaster's own chance of this, stated with the estimate: 30%); middle value at least 8.3-fold (0.92 log units) from the limit.
By their numbers in this assay, from the lowest: compounds 1, 2 and 3 (each within the scatter of the next, the first and the last beyond it). At a limit, above all of these: compound 4.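

In this assay compound 4 stands at > 100000 nM, which is a limit of the assay and not a number. For the compounds shown here, the replacement of ((chloromethyl)carbonyl)amino by 2-chloroethyl on a carbonyl carbon gives an at least 41-fold higher number from compound 1 to compound 4 (1.61 log units; beyond the scatter), the first one-place change and a large one, so with the rest of compound 1 kept, the activity in this read-out depends strongly on the group at this place, something the earlier compounds could not show as all of them hold the chloroacetyl amide. The true size of the step stays unfixed, as only its lower bound can be read: the limit of > 100000 nM in this assay, at which 1 of the 4 values shown sits.

The change removes the urea link and the chloroacetyl unit in one move, so the compounds shown leave open which of these features accounts for the loss. An acetyl or a bromoacetyl group on the same urea link, or a chloroacetyl amide on the benzylamine without the urea link, would separate the contribution of the chlorine from that of the link.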